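Para substituent swap on a pyrrolopyridinone-type core, inhibition in the rat

The source may hold more compounds than are shown below. What is called first, only, known or untested is meant among the compounds shown, and "the series" means these compounds.

Measured compounds:
compound 1, `COc1ccc(N2C(=O)C(C)(C)c3cccnc32)cc1`, 42%
compound 2, `CSc1ccc(N2C(=O)C(C)(C)c3cccnc32)cc1`, 37%

In a functional assay on the whole organism (Pleural cavity) for inhibition, with Rattus norvegicus as the target, at a dose of 25 mg/kg (on this read-out lower numbers stand for less inhibition and higher numbers for more inhibition at the one dose given (going by the name of the read-out)), compound 2 gives 37%, the lowest of the two numbers shown, with compound 1 as its nearest neighbour; the step of a number 5 percentage points lower from compound 1 to compound 2 (within the scatter) lies within the scatter. Within the data shown here, the only recorded step therefore shows that changing the group at this position, methylsulfanyl in place of methoxy on an aromatic carbon, hardly moved the read-out.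

Compound 3, `CC1(C)C(=O)N(c2ccc(Br)cc2)c2ncccc21`, is not yet measured. It differs from compound 2 by bromo in place of methylsulfanyl on an aromatic carbon. Among the measured compounds shown here, the one step that bears on this exchange, at the same position, was a number 5 percentage points lower from compound 1 to compound 2 (within the scatter), so no movement beyond the scatter is expected, and a number 1 percentage points higher from compound 2 to compound 3 (within the scatter) is the step estimated. For compound 3 the expected value in this assay is 38%, with a range from 22% to 54%.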

Compound 3, a percentage reported as inhibition, in the whole organism at one dose (the size of the read-out at that dose, not a potency): 55%
Estimate against measurement, compound 3: 17 percentage points below, outside the stated range (above it).
By their numbers in this assay, from the lowest: compounds 2 and 1 (each within the scatter of the next); then compound 3.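

In this assay bromo in place of methylsulfanyl gives a number 18 percentage points higher from compound 2 to compound 3 (beyond the scatter) and bromo in place of methoxy gives a number 13 percentage points higher from compound 1 to compound 3 (beyond the scatter) and so the group on this aromatic carbon can move the read-out after all. The earlier exchange of methoxy for methylsulfanyl stayed within the scatter, so this position looked insensitive until bromo entered, and among these three compounds only bromo stands apart. Nothing in the data at hand says why bromo differs from the other two groups.

On these data alone, whether chloro or fluoro on the same carbon would behave like bromo stays open. Also open, as far as these compounds go, is what an amine or a carboxylic acid would do there, and whether the gain with bromo would hold at other doses.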